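This account rests on a few compounds, and the source may have more. Where it says the series, first, only, none or still open, it means among the compounds named here.

Of the compounds shown here, two have so far been tested in a functional assay on HCT-15 cells (Homo sapiens) for cytotoxicity; a lower number here means that less compound is needed, a higher number that more compound is needed for the effect. Compound 1 `C=CCCCCCCCC#CC#CC(O)CC(C)=O` gives 4.18 ug/mL in this assay, and compound 2 `CCCCCCCC#CC#CCO` gives 5.9 ug/mL. Among the compounds with values here, compound 2 holds the higher of the two numbers, but its only neighbour, compound 1, lies within the usual scatter of it, so the two cannot really be told apart.

Compound 3 `CCCCCCCC#CC#CC(O)CC(C)=O` has not yet been measured. It differs from compound 2 by 2-oxopropyl in place of hydrogen on a saturated chain carbon bound to an oxygen on a saturated carbon and a triple-bonded carbon. Within the data shown here, no pair of measured compounds differs in exactly that one place, so the size of this step cannot be read off directly. Compound 1, which also carries a 2-oxopropyl group, gives 4.18 ug/mL, a number within the scatter of compound 2, and this suggests the change does not move the number beyond the scatter. Compound 3 is therefore expected to give about 4.5 ug/mL, in a range from 2.5 ug/mL to 8 ug/mL. The expected step of a 1.3-fold lower number from compound 2 to compound 3 (0.12 log units; within the scatter) is within the scatter.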

Compound 3, concentration for half-maximal effect: 3.73 ug/mL
Compound 3: the middle estimate sits 1.2-fold (0.08 log units) above what was measured; the measured number falls inside the stated range.
By their numbers in this assay, from the lowest: compounds 3, 1 and 2 (each within the scatter of the next).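

In this assay the effect of 2-oxopropyl in place of hydrogen on a saturated chain carbon bound to an oxygen on a saturated carbon and a triple-bonded carbon can now be read directly, as a 1.6-fold lower number from compound 2 to compound 3 (0.20 log units; within the scatter), so at this position the added group does not separate the two compounds. The far end of the chain can be read as well: hydrogen in place of vinyl on a saturated chain carbon, seven bonds along the chain from a triple-bonded carbon, gives a 1.1-fold lower number from compound 1 to compound 3 (0.05 log units; within the scatter), and this change does not separate its pair either. No measurement here offers an explanation for these results.

Going by these compounds, whether a carboxylic acid or an amine at the first position would give a step beyond the scatter remains open. So does the effect of a longer chain.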